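Para-substituent swap on the aryl ring of the shared core

A few compounds are considered here, and "the series" means these few. Any claim that something is new, unique, unknown or untested is made for them only; others in the source may bear on it.

Measured compounds in a functional assay on HCT-116 cells (Homo sapiens) for inhibition, read by sulforhodamine B assay, with a stated time of 72 h; a higher number here means a weaker inhibitor, a lower number a stronger inhibitor:
- compound 1 `CC(c1ccc(-c2ccccc2)c(F)c1)c1nnc2n1N=C(c1ccc(C(F)(F)F)cc1)CS2`: 6100 nM
- compound 2 `Cc1ccc(C2=Nn3c(nnc3C(C)c3ccc(-c4ccccc4)c(F)c3)SC2)cc1`: 4800 nM
- compound 3 `CC(C)Cc1ccc(C(C)c2nnc3n2N=C(c2ccc(Cl)cc2)CS3)cc1`: 6700 nM

Compound 2 gives the lowest of the three numbers, but its gap to compound 1 and to compound 3 is within the scatter in each case, so the three compounds cannot be ordered on these data.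

Compound 4 `CC(c1ccc(-c2ccccc2)c(F)c1)c1nnc2n1N=C(c1ccc(Br)cc1)CS2` is not yet measured. Compound 4 differs from compound 2 by bromo in place of methyl on an aromatic carbon.

Among the compounds with values here, the only measured step at the same position is a 1.3-fold lower number from compound 1 to compound 2 (0.10 log units; within the scatter), a change within the scatter. Compound 3, which carries chloro at the corresponding aromatic carbon but a different group on the other side of the core, gives 6700 nM, again close to compound 1 and compound 2. The exchange of groups at this aromatic carbon, whether methyl, trifluoromethyl or chloro, has so far not moved the number beyond the scatter. The same is therefore expected for bromo: the estimated step of a 1.1-fold higher number from compound 2 to compound 4 (0.06 log units; within the scatter) from compound 2 to compound 4 should stay within the scatter, with no direction implied.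

Compound 4 is therefore estimated at 5500 nM in this assay, with a range from 2500 nM to 12000 nM.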

Compound 4, half-maximal inhibitory concentration: 7100 nM
Estimate against measurement, compound 4: 1.3-fold (0.11 log units) below, within the range that was stated.
By their numbers in this assay, from the lowest: compounds 2, 1, 3 and 4 (each within the scatter of the next).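

In this assay, bromo extends the set of groups read at this aromatic carbon, para to a large group, on an otherwise unchanged structure. The exchange for methyl gives a 1.5-fold higher number from compound 2 to compound 4 (0.17 log units; within the scatter) and the exchange for trifluoromethyl gives a 1.2-fold higher number from compound 1 to compound 4 (0.07 log units; within the scatter), so each of the three pairs among methyl, trifluoromethyl and bromo now has a direct reading, including a 1.3-fold lower number from compound 1 to compound 2 (0.10 log units; within the scatter), and none lies beyond the scatter. Across compound 1, compound 2 and compound 4, this position therefore shows no measurable preference among these three groups in this assay, and no measurement here offers an explanation for that flat reading.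

The compounds shown leave open whether a group of another kind at this aromatic carbon, such as an amine, a carboxylic acid or a longer chain, would move the number beyond the scatter. They also leave open whether the same flat reading would hold with another group on the other side of the shared core, since each step read here keeps that side unchanged.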